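A few compounds are considered here, and "the series" means these few. Any claim that something is new, unique, unknown or untested is made for them only; others in the source may bear on it.

Three esters of a methyl-bearing piperidinyl alcohol have been tested so far. Compound 1 `COc1cc(OC)cc(C(=O)OC2CCN(C)CC2)c1` carries two methoxy groups on its aromatic ring; compound 2 `Cc1cccc(C)c1C(=O)OC1CCN(C)CC1` carries two methyl groups; compound 3 `CN1CCC(OC(=O)c2ccc(C(C)(C)C)cc2)CC1` carries a tert-butyl group. In a functional assay on the whole organism with Mus musculus as the target (a higher number here means a more potent compound, by a factor of ten per unit of this negative logarithm, a lower number a less potent compound), compound 1 gives 1.53, compound 2 gives 1.27, and compound 3 gives 1.13. Compound 3 thus holds the lowest of the three numbers, although its gap to compound 2 lies within the scatter of this assay and only its gap to compound 1 lies beyond it.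

Compound 4 `CN1CCC(OC(=O)c2ccc([N+](=O)[O-])cc2)CC1` is the next member and has not yet been measured in this assay. It differs from compound 3 in one place: nitro in place of tert-butyl on an aromatic carbon. Going by the values given here, no step between two measured compounds mirrors this exchange, so there is nothing in the measured set from which its size could be read.

Given the narrow spread of the three measured values, the step is expected to be small, with no direction expected beyond the scatter; the estimate for the step is a number 0.07 log units higher from compound 3 to compound 4 (within the scatter). Compound 4 is therefore expected to give about 1.2 in this assay, within a range from 0.7 to 1.7.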

Compound 4, logarithm of the reciprocal of the active concentration, log(1/C): 1.14
The estimate for compound 4 lay 0.06 log units above the measured number; measured number inside the range.
By their numbers in this assay, from the lowest: compounds 3, 4, 2 and 1 (each within the scatter of the next, the first and the last beyond it).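

Going by these compounds alone, exchanging tert-butyl for nitro on an aromatic carbon, para to a large group, gives in this assay a number 0.01 log units higher from compound 3 to compound 4 (within the scatter), the only step so far read between two compounds that differ in one place. At this position, then, two groups with little in common by count, one of four carbon atoms with no hydrogen-bond acceptors and one of a nitrogen and two oxygen atoms with two hydrogen-bond acceptors, give numbers that cannot be told apart in this assay. Nothing available explains this result, and no measurement bears on it.

A single step within the scatter does not show whether this position tolerates any group, since an amine, a carboxylic acid or a longer alkyl chain in the same place might still move the number beyond the scatter. It also leaves open whether an unsubstituted ring would match compound 3 and compound 4, and whether the same exchange would give so small a step on another carbon of the ring.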